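Removing the phenyl from compound 3's benzyl group

The source may hold more compounds than are shown below. What is called first, only, known or untested is meant among the compounds shown, and "the series" means these compounds.

In a functional assay (microsomes, liver) with Rattus norvegicus as the target (a lower number here means a stronger inhibitor, a higher number a weaker inhibitor), compound 3 (`Cc1c(C)c2c(c(C)c1N)CC(C)(COCc1ccccc1)O2`) gives 280 nM and sits within the scatter of compound 1 (`Cc1c(C)c2c(c(C)c1N)CC(C)(CSc1ccccc1)O2`) at 270 nM while compound 2 (`Cc1c(C)c2c(c(C)c1N)CC(C)(CSc1ccncc1)O2`) at 630 nM lies apart from it, beyond the scatter. Compound 4 (`COCC1(C)Cc2c(C)c(N)c(C)c(C)c2O1`) differs from compound 3 by one change (hydrogen in place of phenyl on a saturated chain carbon bound to an oxygen on a saturated carbon) with hydrogen in place of phenyl on a saturated chain carbon bound to an oxygen on a saturated carbon, which reads as benzyl to methyl. Among the compounds with values here, the only measured step, pyridin-4-yl in place of phenyl on a sulfur, gave a 2.3-fold higher number from compound 1 to compound 2 (0.37 log units; beyond the scatter) and swaps one ring for another without removing it, so it is only a loose guide. A similarly modest step (a 2.0-fold higher number from compound 3 to compound 4 (0.29 log units; within the scatter)) towards a higher number is therefore expected in this assay with real uncertainty. For compound 4 the estimated value is 550 nM with an expected range from 220 nM to 1400 nM as its likely span.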

Compound 4, half-maximal inhibitory concentration: 300 nM
Estimate against measurement, compound 4: 1.8-fold (0.26 log units) above; the range from low to high includes it.
By their numbers in this assay, from the lowest: compounds 1, 3 and 4 (each within the scatter of the next); then compound 2.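

In this assay the switch from benzyl to methyl gives a 1.1-fold higher number from compound 3 to compound 4 (0.03 log units; within the scatter) and so the phenyl at this place is not needed to keep the number. Methoxy in place of phenylsulfanyl gives a 1.1-fold higher number from compound 1 to compound 4 (0.05 log units; within the scatter) and methoxy in place of (pyridin-4-yl)sulfanyl gives a 2.1-fold lower number from compound 2 to compound 4 (0.32 log units; beyond the scatter) so a side chain without any ring matches compound 1 and compound 3, and only compound 2 stands apart. Nothing measured here explains why the ring can go. Still open, on these data alone, is whether an amine or a carboxylic acid in place of the methyl would hold the number or move it.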